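This account rests on a few compounds, and the source may have more. Where it says the series, first, only, none or still open, it means among the compounds named here.

Among the measured compounds shown here, compound 2 `Cc1cccc(NC(=O)CN2CCC(c3ccccc3)CC2)c1` stands as the stronger of the two compounds measured so far. In a functional assay on cells for antagonist activity at D(4) dopamine receptor (Homo sapiens), read by TR-FRET and cAMP accumulation, with a stated time of 30 min (on this read-out higher numbers stand for weaker inhibition and lower numbers for stronger inhibition), compound 2 gives 2 nM, while compound 1 `Cc1ccc(C2CCN(CC(=O)Nc3cccc(C)c3)CC2)nc1` gives 453 nM. For the measured compounds named here, the single measured step between them, a 230-fold lower number from compound 1 to compound 2 (2.36 log units; beyond the scatter), exchanged the whole group on the saturated ring carbon. Compound 3 `Cc1cccc(NC(=O)CN2CCC(c3ccc(Cl)cc3)CC2)c1` keeps everything in compound 2 and differs in one place: chloro in place of hydrogen on an aromatic carbon, on an aromatic carbon of a six-membered aromatic ring of carbon only, para to a large group; cut one bond further out, the same change reads phenyl to 4-chlorophenyl. The step from compound 1 to compound 2 shows that the ring on the saturated carbon governs the number strongly, but it replaced the entire ring rather than one hydrogen on it, so it does not show how a single chloro at this position will act. Going by the values given here, no measured step bears directly on the change. The expectation for compound 3 is therefore a step of a 1.3-fold higher number from compound 2 to compound 3 (0.10 log units; within the scatter) in this assay, within the scatter. Compound 3 is estimated at 2.5 nM, with a range from 0.7 nM to 9 nM.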

Compound 3, half-maximal inhibitory concentration: 70200 nM
Compound 3: middle estimate off by 28000-fold (4.45 log units), on the low side; measured number outside the range, above it.
By their numbers in this assay, from the lowest: compound 2; then compound 1; then compound 3.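

In this assay, the step of a 35000-fold higher number from compound 2 to compound 3 (4.55 log units; beyond the scatter) shows that this position is far from tolerant: one chloro on the aromatic ring, para to a large group, moves the number even further than the whole-ring exchange of a 230-fold lower number from compound 1 to compound 2 (2.36 log units; beyond the scatter) did. The step of a 150-fold higher number from compound 1 to compound 3 (2.19 log units; beyond the scatter) adds that 4-chlorophenyl on the saturated ring carbon also sits on the weaker side of 5-methylpyridin-2-yl, so among these three compounds, having a six-membered aromatic ring at that carbon does not by itself give a low number, and the hydrogen-to-chloro change alone takes compound 3 from the lowest number to the highest. No measurement here accounts for this large loss of inhibition.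

The compounds shown leave open whether fluoro, methyl or methoxy in the same place would raise the number as sharply as chloro, or whether this result is particular to chloro. They also leave open whether a chloro on a different carbon of the same ring would produce a similar step.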